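Nitro for cyano on a piperidinyl benzoate ester

The compounds below may be only part of what the source reports. "The series", "measured", "known", "first", "only" and "open" are said of these compounds alone.

Three esters of the same core have been tested in a functional assay on the whole organism with Mus musculus as the target; a higher number here means a more potent compound, by a factor of ten per unit of this negative logarithm, a lower number a less potent compound. Compound 1 `CN1CCC(OC(=O)c2ccc(C#N)cc2)CC1` gives 1.65. Compound 3 `COc1cc(OC)c(C(=O)OC2CCN(C)CC2)c(OC)c1` gives 1.47, and compound 2 `CN1CCC(OC(=O)c2cccc(C#N)c2)CC1` gives 1.39. The number for compound 1 is the highest of the three, but both other numbers lie within the usual scatter of it: compound 3 is nearest and compound 2 furthest, and neither gap can be read as a real difference in potency. Among the measured compounds shown here, no pair among the three differs in only one place, so no single step between measured compounds is available to guide an expectation.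

Compound 4 `CN1CCC(OC(=O)c2ccc([N+](=O)[O-])cc2)CC1` differs from compound 1 in one place: nitro in place of cyano on an aromatic carbon. The change sits on the aromatic ring para to a large group, and the rest of the structure is untouched. For the measured compounds named here, with no measured step of this kind to draw on, the expectation is that the step from compound 1 to compound 4 in this assay is of no size beyond the scatter, in either direction; the step of a number 0.05 log units higher from compound 1 to compound 4 (within the scatter) expresses this estimate. For compound 4 the estimated value in this assay is 1.7, with a range from 1.2 to 2.2.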

Compound 4, logarithm of the reciprocal of the active concentration, log(1/C): 1.14
The estimate for compound 4 lay 0.56 log units above the measured number; the whole stated range lies above it.
By their numbers in this assay, from the lowest: compounds 4, 2, 3 and 1 (each within the scatter of the next, the first and the last beyond it).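

In this assay the replacement of cyano by nitro on an aromatic carbon, para to a large group, gives a number 0.51 log units lower from compound 1 to compound 4 (beyond the scatter), so this first single-place comparison in the set shows that the position does not treat the two groups alike. Neither group brings a ring or a net charge, and the count printed for each differs only slightly, with 2 heavy atoms and 1 hydrogen-bond acceptor leaving and 3 heavy atoms and 2 hydrogen-bond acceptors entering, so a small change at this place is enough for a step beyond the scatter. No measurement offered here accounts for the step, and the reason for it remains unknown.

The compounds shown leave open whether other groups on this aromatic carbon, such as an amine or a carboxylic acid, would stay level with cyano or fall as nitro does. They also leave open whether nitro in place of cyano would give a step of similar size on compound 2, where the cyano group sits elsewhere on the ring.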